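Aryl hydrazone exchange on the shared core, cytotoxicity notes

A few compounds are considered here, and "the series" means these few. Any claim that something is new, unique, unknown or untested is made for them only; others in the source may bear on it.

Within the data shown here, in a functional assay on HT-29 cells (Homo sapiens) for cytotoxicity, read by MTT assay, with a stated time of 72 h (a lower number here means a stronger inhibitor, a higher number a weaker inhibitor), compound 3 `CN(C)CCn1cnnc1-c1cc(Oc2ccc(NC(=O)N/N=C/c3ccc(O)c(O)c3)cc2F)ccn1` gives 1890 nM and stands second highest of the three numbers known so far. Nearest is compound 2 `COc1cc(/C=N/NC(=O)Nc2ccc(Oc3ccnc(-c4nncn4CCN(C)C)c3)c(F)c2)cc(OC)c1OC`, which gives 3620 nM, a step of a 1.9-fold lower number from compound 2 to compound 3 (0.28 log units; within the scatter). Furthest is compound 1 `CN(C)CCn1cnnc1-c1cc(Oc2ccc(NC(=O)N/N=C/c3c(Cl)cccc3Cl)cc2F)ccn1`, which gives 280 nM, a step of a 6.8-fold higher number from compound 1 to compound 3 (0.83 log units; beyond the scatter). The change to compound 4 `CN(C)CCn1cnnc1-c1cc(Oc2ccc(NC(=O)N/N=C/c3c(O)ccc4ccccc34)cc2F)ccn1` is 2-hydroxynaphthalen-1-yl in place of 3,4-dihydroxyphenyl on a carbon with a double bond to nitrogen. The measured steps at this same place are a 13-fold higher number from compound 1 to compound 2 (1.11 log units; beyond the scatter), a 6.8-fold higher number from compound 1 to compound 3 (0.83 log units; beyond the scatter) and a 1.9-fold lower number from compound 2 to compound 3 (0.28 log units; within the scatter); together they show that exchanging the aryl group on the carbon double-bonded to nitrogen can shift this assay well beyond the scatter, with compound 1 giving the lowest number and the two oxygen-bearing phenyls of compound 2 and compound 3 lying within the scatter of each other. Among the measured compounds shown here, no measured step tests a fused second ring or a single hydroxyl, so the forecast rests on the span these three aryl groups cover. For compound 4 a modest step toward a lower number is expected, a 2.1-fold lower number from compound 3 to compound 4 (0.32 log units; beyond the scatter). The estimate for compound 4 in this assay is 900 nM, with a range from 250 nM to 3200 nM.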

Compound 4, half-maximal inhibitory concentration: 670 nM
Beside the measured number, compound 4's estimate is 1.3-fold (0.13 log units) above it; measured number inside the range.
By their numbers in this assay, from the lowest: compound 1; then compound 4; then compounds 3 and 2 (each within the scatter of the next).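

In this assay the 2-hydroxynaphthalen-1-yl group sets compound 4 apart from both oxygen-bearing phenyls, with a 2.8-fold lower number from compound 3 to compound 4 (0.45 log units; beyond the scatter) and a 5.4-fold lower number from compound 2 to compound 4 (0.73 log units; beyond the scatter) both beyond the scatter. The position therefore reads more finely than the earlier split between the 2,6-dichlorophenyl of compound 1 and two phenyls within the scatter of each other, yet a 2.4-fold higher number from compound 1 to compound 4 (0.38 log units; beyond the scatter) keeps compound 1 lowest of the four. Carrying a hydroxyl does not by itself fix the number here, since compound 3 and compound 4 both carry one and still differ beyond the scatter.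

The shown compounds do not separate the second ring from the loss of a hydroxyl, and a naphthalenyl group without the hydroxyl, an aryl amine or an aryl carboxylic acid at this position would bear on that question. No supporting measurement is available to explain these steps.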